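The source may hold more compounds than are shown below. What is called first, only, known or untested is meant among the compounds shown, and "the series" means these compounds.

Measured compounds:
compound 1, `O=C1NC(=O)/C(=C\c2ccc(OCC(=O)N3N=C(c4ccccc4)CC3c3ccccc3Cl)cc2)S1`: 1200 nM
compound 2, `Cc1ccc(C2CC(c3ccccc3)=NN2C(=O)COc2ccc(/C=C3/SC(=O)NC3=O)cc2)cc1`: 1200 nM

In an assay on cells for inhibition of histone deacetylase 4 (Homo sapiens), read by fluorescence, with a stated time of 30 min (a higher number here means a weaker inhibitor, a lower number a stronger inhibitor), compound 2 stands level with compound 1; the step of no change at the digits printed from compound 1 to compound 2 (within the scatter) lies within the scatter. Compound 3, `O=C1NC(=O)/C(=C\c2ccc(OCC(=O)N3N=C(c4ccccc4)CC3c3ccc(Cl)c(Cl)c3)cc2)S1`, differs from compound 2 by 3,4-dichlorophenyl in place of 4-methylphenyl on a saturated ring carbon. Among the measured compounds shown here, the only measured step that bears on this, likewise an exchange of the aryl group on a saturated ring carbon, was no change at the digits printed from compound 1 to compound 2 (within the scatter). No step beyond the scatter is therefore expected in this assay, and the estimated change is no change at the digits printed from compound 2 to compound 3 (within the scatter). Compound 3 is expected to give about 1200 nM, within the range 600 nM to 2400 nM.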

Compound 3, half-maximal inhibitory concentration: 700 nM
Compound 3: the middle estimate sits 1.7-fold (0.23 log units) above what was measured; measured number inside the range.
By their numbers in this assay, from the lowest: compounds 3, 1 and 2 (each within the scatter of the next).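

In this assay, 3,4-dichlorophenyl on the saturated ring carbon gives a 1.7-fold lower number from compound 2 to compound 3 (0.23 log units; within the scatter) and a 1.7-fold lower number from compound 1 to compound 3 (0.23 log units; within the scatter). The position therefore accepts a third aryl group, now carrying two chlorine atoms, and the assay still does not separate it from 4-methylphenyl or 2-chlorophenyl. No supporting data bear on these small steps.

All three groups here are substituted phenyl rings. From the compounds shown here alone, whether an amine, a carboxylic acid or a longer chain at this carbon would give a step beyond the scatter remains open.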